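This account rests on a few compounds, and the source may have more. Where it says the series, first, only, none or still open, it means among the compounds named here.

The core of compound 1 (`O=C1COc2ccc(-c3cnc(Cl)c(NS(=O)(=O)c4ccc(F)cc4)c3)cc2N1C1CCCCC1`) carries a cyclohexyl on an amide-type nitrogen in a ring. In a functional assay on MCF7 cells (Homo sapiens) for antiproliferative activity, read by MTT assay, with a stated time of 72 h (on this read-out lower numbers stand for stronger inhibition and higher numbers for weaker inhibition), compound 1 gives > 40000 nM, which is a limit of the assay and not a number. Compound 1 therefore stands at the limit of > 40000 nM in this assay, at which 1 of the 2 values shown sits.

Compound 2 (`COc1ncc(-c2ccc3c(c2)N(C2CCCCC2)C(=O)CO3)cc1NS(=O)(=O)c1ccc(F)cc1`) has methoxy in place of chloro on an aromatic carbon and gives 30100 nM in this assay. Within the data shown here, this is the only measured step, an at least 1.3-fold lower number from compound 1 to compound 2 (0.12 log units; that floor lies within the scatter), and it lies at a different place from the change followed here.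

Compound 3 (`CC(C)N1C(=O)COc2ccc(-c3cnc(Cl)c(NS(=O)(=O)c4ccc(F)cc4)c3)cc21`) keeps the chloro of compound 1 and differs at the amide-type nitrogen: isopropyl in place of cyclohexyl on an amide-type nitrogen in a ring. Among the measured compounds shown here, no measured step touches that nitrogen, so the step of an at least 1.3-fold lower number from compound 1 to compound 2 (0.12 log units; that floor lies within the scatter) gives neither a size nor a direction for this change. No step beyond the scatter is therefore expected in this assay, and compound 3 may again report only a limit. The estimated step is an at least 1.1-fold lower number from compound 1 to compound 3 (0.05 log units; that floor lies within the scatter). For compound 3 the expected value is 35000 nM, with an estimated range of 12000 nM to 70000 nM.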

Compound 3, half-maximal inhibitory concentration: 26600 nM
Estimate against measurement, compound 3: 1.3-fold (0.12 log units) above; low and high end bracket the measured number.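

Among these compounds, with compound 3, the first change at the amide-type nitrogen is on record: with the chloro kept, isopropyl in place of cyclohexyl gives a measured number in this assay, where the earlier compounds carried cyclohexyl at this position and so said nothing about it. The change, which removes a ring and leaves 3 heavy atoms in place of 6, comes out as an at least 1.5-fold lower number from compound 1 to compound 3 (0.17 log units; that floor lies within the scatter), so neither its true size nor any real effect of this position can be taken from it. This step stands only as a floor because compound 1 sits at a limit of the assay and not at a number: the limit of > 40000 nM in this assay, at which 1 of the 3 values shown sits.

The compounds shown leave open whether that floor hides a step beyond the scatter, and whether the same change would read alike with methoxy in place of chloro. They also leave open how the position would read in this assay with methyl, with a longer chain such as n-butyl, or with a chain ending in an amine or a carboxylic acid on that nitrogen.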